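A few compounds are considered here, and "the series" means these few. Any claim that something is new, unique, unknown or untested is made for them only; others in the source may bear on it.

The study follows two compounds with measured values and one without. Compound 1 `C=c1[nH]c(=O)/c(=C/c2ccc(C(=O)OC)cc2)[nH]c1=O` was tested in a functional assay on Huh7.5.1 cells (Homo sapiens) for cytotoxicity, read by MTT assay, with a stated time of 72 h; a higher number here means that more compound is tolerated, a lower number that less compound is tolerated. In this assay compound 1 gives > 20000 nM, which is a limit of the assay and not a number. Compound 2 `C=CC(C)(C)c1[nH]c2ccccc2c1/C=C1\NC(=O)[C@H](C)NC1=O` was tested in the same way. In this assay compound 2 gives > 20000 nM, again a limit rather than a number. Compound 1 therefore stands at the limit of > 20000 nM in this assay, at which 2 of the 2 values shown sit, and no ordering among the measured compounds can be read from these values. Compound 3 `C=c1[nH]c(=O)/c(=C/c2ccc(OC)cc2)[nH]c1=O` has not yet been measured in this assay. It differs from compound 1 by methoxy in place of methoxycarbonyl on an aromatic carbon. Among the compounds with values here, no step between measured compounds is available, so its size can only be expected: with both measured compounds sitting at the limit, no step beyond the scatter in this assay is expected in either direction. For compound 3 the estimated value in this assay is 20000 nM, within an expected range from 10000 nM to 40000 nM. This step is expected to be a number no higher from compound 1 to compound 3 (the limit leaves the size open).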

Compound 3, half-maximal cytotoxic concentration: > 20000 nM
Compound 3: a limit, no number; the forecaster's own chance of this, stated with the estimate: 85%; the middle value sits exactly at the limit.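

Compound 3 gives > 20000 nM in this assay, a limit and not a number. Within the data shown here, compound 1 also stands at a limit, so no step between compound 1 and compound 3 can be read. The compounds shown leave open what number any of them would give: the limit of > 20000 nM in this assay, at which 3 of the 3 values shown sit.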